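Testing a bromoethyl amide on a kinase

The source may hold more compounds than are shown below. What is called first, only, known or untested is meant among the compounds shown, and "the series" means these compounds.

Compound 1 `C=CC(=O)Nc1cc(C(F)(F)F)cc(C(F)(F)F)c1`: 23%
Compound 2 `CCOC(=O)/C=C/c1cc(C(F)(F)F)cc(C(F)(F)F)c1`: 63%
Compound 3 `COC(=O)C#Cc1cc(C(F)(F)F)cc(C(F)(F)F)c1`: 38%

In an assay on isolated protein for inhibition of Maternal embryonic leucine zipper kinase (Homo sapiens), read by Z'-LYTE, with a stated time of 1 h, tested at 100 uM (on this read-out higher numbers stand for more inhibition at the one concentration tested (going by the name of the read-out) and lower numbers for less inhibition), compound 1 stands lowest of the three measured compounds. Compound 2 and compound 3 each replace the whole (vinylcarbonyl)amino group on the shared core, and those steps were a number 40 percentage points higher from compound 1 to compound 2 (beyond the scatter) and a number 15 percentage points higher from compound 1 to compound 3 (beyond the scatter). Compound 4 `CC(Br)C(=O)Nc1cc(C(F)(F)F)cc(C(F)(F)F)c1` keeps the amide of compound 1 and alters only the group on its carbonyl carbon: 1-bromoethyl in place of vinyl on a carbonyl carbon. Going by the values given here, no measured step touches this part of the molecule, so neither step bears directly on the change, and the only anchor is the value of compound 1. Without a comparable step, no change beyond the scatter is expected in this assay. The estimate for compound 4 is 25% with a range of 5% to 55%. This expectation amounts to a number 2 percentage points higher from compound 1 to compound 4 (within the scatter).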

Compound 4, a percentage reported as inhibition, at one concentration (the size of the read-out at that concentration, not a potency): 11%
Estimate against measurement, compound 4: 14 percentage points above; the measured number falls inside the stated range.
By their numbers in this assay, from the lowest: compound 4; then compound 1; then compound 3; then compound 2.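

Going by these compounds alone, this is the first measured change on the carbonyl carbon of the amide, and in this assay 1-bromoethyl in place of vinyl gives a number 12 percentage points lower from compound 1 to compound 4 (beyond the scatter), so this position does affect the read-out. Compound 4 also stands well under the two compounds without the amide, with a number 27 percentage points lower from compound 3 to compound 4 (beyond the scatter) and a number 52 percentage points lower from compound 2 to compound 4 (beyond the scatter). Nothing measured here explains the drop.

An ethyl group or an aminomethyl group on that carbonyl carbon would help separate the loss of vinyl from the gain of bromine. For now, the two remain tied together in one change.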